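The source may hold more compounds than are shown below. What is called first, only, known or untested is meant among the compounds shown, and "the series" means these compounds.

In a functional assay on cells (Neutrophil, Homo sapiens) for inhibition, with a stated time of 10 min (on this read-out higher numbers stand for weaker inhibition and lower numbers for stronger inhibition), the values so far are:
- compound 1 `CCOC(=O)c1cnn(CC(C)O)c1NC(=O)Nc1ccc(F)cc1` gives 0.2 nM
- compound 2 `CCOC(=O)c1cnn(CC(O)CC)c1NC(=O)Nc1ccccc1F` gives 0.0016 nM

Compound 2 holds the lower number of the two, and its gap to compound 1 lies beyond the scatter. Compound 3 `CCOC(=O)c1cnn(CC(C)O)c1NC(=O)Nc1ccccc1F` departs from compound 2 by one change: hydrogen in place of methyl on a saturated chain carbon, two bonds along the chain from an oxygen on a saturated carbon (2-hydroxybutyl to 2-hydroxypropyl). For the measured compounds named here, no measured pair isolates this change. The 2-hydroxypropyl chain also stands in compound 1, at 0.2 nM in this assay for a compound that differs elsewhere too, so it is only a loose guide. A moderate move to a higher number, meaning weaker inhibition and probably beyond the scatter, is expected. The expected step runs a 13-fold higher number from compound 2 to compound 3 (1.10 log units; beyond the scatter) in this estimate. Compound 3 is estimated at 0.02 nM, with an expected range of 0.002 nM to 0.3 nM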

Compound 3, half-maximal inhibitory concentration: 0.00055 nM
Compound 3: the middle estimate sits 36-fold (1.56 log units) above what was measured; the measured number lies below the stated range.
By their numbers in this assay, from the lowest: compound 3; then compound 2; then compound 1.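

In this assay, hydrogen in place of methyl on the saturated chain carbon gives a 2.9-fold lower number from compound 2 to compound 3 (0.46 log units; beyond the scatter), so the shorter 2-hydroxypropyl chain is favoured over 2-hydroxybutyl in this pair. With the 2-hydroxypropyl chain held constant, 2-fluorophenyl in place of 4-fluorophenyl gives a 360-fold lower number from compound 1 to compound 3 (2.56 log units; beyond the scatter), a much larger step than the one on the chain. Nothing available explains either step.

Going by these compounds, how a longer chain than 2-hydroxybutyl, or an amine in place of the chain's hydroxyl, would read remains open. On these data alone, the unsubstituted phenyl group is also open.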